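The source may report more compounds than this note shows. Statements on the series, on what has been measured and on what is new or still open speak of the compounds shown alone.

Measured so far:
- compound 1, `COc1cc(CCc2ccc(F)cc2)cc(OC)c1O`: 10700 nM
- compound 2, `COc1cc(CCc2cccc(Cl)c2Cl)cc(OC)c1O`: 11 nM
- compound 3, `COc1cc(CCc2cccc(F)c2)cc(OC)c1O`: 2970 nM

In a functional assay on MKN-45 cells (Homo sapiens) for antiproliferative activity, read by MTT assay, with a stated time of 72 h (a higher number here means a weaker inhibitor, a lower number a stronger inhibitor), compound 1 gives 10700 nM, the highest of the three numbers. Compound 3 stands nearest to it, and its lower value is beyond the scatter. Compound 2 stands furthest away, with the lowest number of the set by a wide margin, also beyond the scatter. The shared core is the same in all three; the measured compounds differ only in what sits on the outer aromatic ring.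

Compound 4, `COc1cc(CCc2ccc(Cl)cc2)cc(OC)c1O`, has not yet been measured in this assay. Relative to compound 1 the change is chloro in place of fluoro on an aromatic carbon. For the measured compounds named here, no step between measured compounds isolates this exchange, so its size is not known from the data. What the numbers show is that compound 2, which carries chloro and not fluoro on its ring, gives 11 nM while compound 1 gives 10700 nM, though compound 2 differs from compound 1 in more than this one exchange.

On that basis a step in the lower direction, larger than the scatter but far short of the gap to compound 2, is expected: the estimate for compound 4 is 2500 nM, with a range of 400 nM to 12000 nM, a step from compound 1 to compound 4 of a 4.3-fold lower number from compound 1 to compound 4 (0.63 log units; beyond the scatter).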

Compound 4, half-maximal inhibitory concentration: > 25000 nM
Compound 4: no number, only a limit; the forecaster's own chance of this, stated with the estimate: 5%; middle value at least 10-fold (1.00 log units) from the limit.
By their numbers in this assay, from the lowest: compound 2; then compound 3; then compound 1. At a limit, above all of these: compound 4.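

In this assay compound 4 gives > 25000 nM, which is a limit of the assay and not a number. Chloro in place of fluoro on an aromatic carbon, para to a large group, gives an at least 2.3-fold higher number from compound 1 to compound 4 (0.36 log units; beyond the scatter), the first read in this series of a single exchange at one place, and at this position it moves the number up, not down, by a step beyond the scatter. Only the direction and the minimum size of the step can be read, and how far compound 4 lies from compound 1 stays unknown: the limit of > 25000 nM in this assay, at which 1 of the 4 values shown sits.

The compounds shown leave open how the number would respond to a group of another kind at this same place, such as an amine, a carboxylic acid or a longer chain such as propyl, since fluoro and chloro are the only two groups compared here. For the compounds shown here, they also leave open whether chloro in place of fluoro on another carbon of the same ring moves the number in the same direction, as no second pair differing in that one exchange is available.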